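A few compounds are considered here, and "the series" means these few. Any claim that something is new, unique, unknown or untested is made for them only; others in the source may bear on it.

Measured so far in a functional assay on K562 cells (Homo sapiens) for antiproliferative activity, read by resazurin assay, with a stated time of 72 h; on this read-out lower numbers stand for stronger inhibition of growth and higher numbers for weaker inhibition of growth:
- compound 1 `CN(C)C1=NN(c2ccccc2)CN(c2ccccc2Cl)C1=O` gives 5.8 ug/mL
- compound 2 `O=C1C(N2CCCC2)=NN(c2ccccc2)CN1c1ccccc1Cl` gives 5.2 ug/mL
- compound 3 `O=C1C(N2CCCCC2)=NN(c2ccccc2)CN1c1ccccc1Cl` gives 42 ug/mL

Compound 2 sits at the low end of these numbers, a place it shares (a 1.1-fold lower number from compound 1 to compound 2 (0.05 log units; within the scatter)) and well clear of the top (an 8.1-fold higher number from compound 2 to compound 3 (0.91 log units; beyond the scatter)). The next compound is compound 4 `O=C1C(N2CCCC2)=NN(c2ccc(Cl)cc2)CN1c1ccccc1Cl` with chloro in place of hydrogen on an aromatic carbon, phenyl to 4-chlorophenyl. Among the measured compounds shown here, no measured step touches this ring. All three exchange the amine group, so a 7.2-fold higher number from compound 1 to compound 3 (0.86 log units; beyond the scatter) and the other two are only loose guides to how far this assay can move. The expected result is a 1.2-fold lower number from compound 2 to compound 4 (0.06 log units; within the scatter) and so no step beyond the scatter. For compound 4 the estimated value is 4.5 ug/mL with an expected range from 1.5 ug/mL to 15 ug/mL in this read-out.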

Compound 4, concentration for 50% growth inhibition: 8.6 ug/mL
Beside the measured number, compound 4's estimate is 1.9-fold (0.28 log units) below it; the measured number falls inside the stated range.
By their numbers in this assay, from the lowest: compounds 2, 1 and 4 (each within the scatter of the next); then compound 3.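

In this assay, among the compounds shown here, the phenyl ring is changed for the first time, and a 1.7-fold higher number from compound 2 to compound 4 (0.22 log units; within the scatter) stays within the scatter. Chloro on this aromatic carbon, para to a large group, is therefore tolerated in the pyrrolidin-1-yl series, whereas the amine exchange (an 8.1-fold higher number from compound 2 to compound 3 (0.91 log units; beyond the scatter)) goes beyond the scatter. No measurement bears on the reason for this result.

From the compounds shown here alone, whether a methoxy, nitrile or carboxylic acid group would be tolerated at this position remains open. Also open, going by these compounds, is whether 4-chlorophenyl behaves the same way alongside dimethylamino or piperidin-1-yl.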